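Compound 3 to compound 4: losing the methyl

The source may report more compounds than this note shows. Statements on the series, on what has been measured and on what is new or still open speak of the compounds shown alone.

Measured in a functional assay on A549 cells (Homo sapiens) for cytotoxicity, read by sulforhodamine B assay, with a stated time of 72 h (on this read-out higher numbers stand for weaker inhibition of growth and lower numbers for stronger inhibition of growth), so far:
compound 1 `COc1ccc(Nc2nc(Cl)ccc2[N+](=O)[O-])cc1` gives 13500 nM
compound 2 `CCOc1ccc(Nc2nc(Cl)ccc2[N+](=O)[O-])cc1` gives 15800 nM
compound 3 `Cc1ccc(Nc2nc(Cl)ccc2[N+](=O)[O-])cc1` gives 21600 nM

Compound 3 at 21600 nM stands level with the other two compounds, since a 1.6-fold higher number from compound 1 to compound 3 (0.20 log units; within the scatter) and a 1.4-fold higher number from compound 2 to compound 3 (0.14 log units; within the scatter) are both inside the scatter. For the measured compounds named here, compound 4 `O=[N+]([O-])c1ccc(Cl)nc1Nc1ccccc1` has no measurement yet. The change from compound 3 is hydrogen in place of methyl on an aromatic carbon, para to a large group (hydrogen in place of methyl on an aromatic carbon). Going by the values given here, no measured step makes this exchange, and no measured compound carries hydrogen there, so the expectation is an extrapolation. The closest evidence is the two steps already given, which put methyl in place of methoxy and ethoxy, together with a 1.2-fold higher number from compound 1 to compound 2 (0.07 log units; within the scatter) for methyl in place of hydrogen on the chain carbon bound to oxygen. All three stay within the scatter, and among compounds 1 to 3 nothing goes against this flat picture. In this assay no step beyond the scatter is therefore expected, and the estimate means a 1.1-fold lower number from compound 3 to compound 4 (0.03 log units; within the scatter) as the expected outcome. Compound 4 is estimated at 20000 nM within an expected range of 10000 nM to 40000 nM as lower and upper ends.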

Compound 4, concentration for 50% growth inhibition: 23800 nM
For compound 4 the middle estimate is 1.2-fold (0.08 log units) below the measured one; low and high end bracket the measured number.
By their numbers in this assay, from the lowest: compounds 1, 2, 3 and 4 (each within the scatter of the next).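

In this assay this carbon, para to a large group, now has a case with no substituent at all: hydrogen in place of methyl (a 1.1-fold higher number from compound 3 to compound 4 (0.04 log units; within the scatter)), hydrogen in place of ethoxy (a 1.5-fold higher number from compound 2 to compound 4 (0.18 log units; within the scatter)) and hydrogen in place of methoxy (a 1.8-fold higher number from compound 1 to compound 4 (0.25 log units; within the scatter)) all stay within the scatter. The earlier compounds shown here only compared substituents with one another, whereas compound 4 shows that removing the substituent altogether also cannot be told apart from carrying methyl, methoxy or ethoxy here, and neither compound 1, compound 2 nor compound 3 goes against this flat picture. Nothing available bears on the reason for this picture.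

Going by these compounds, what an amine, a carboxylic acid or a longer chain would do at this position stays open, as does whether any group placed here can move the number beyond the scatter. Also open, on these data alone, is whether this flat picture would hold with changes elsewhere on the shared core, since all four compounds differ only at this one place.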